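The source may hold more compounds than are shown below. What is called first, only, known or untested is meant among the compounds shown, and "the series" means these compounds.

Three compounds sharing a dichlorinated core and a dihydroxylated side chain have been tested in a functional assay on KB cells (Homo sapiens) for inhibition; on this read-out lower numbers stand for stronger inhibition and higher numbers for weaker inhibition. Compound 1 `OCC(CO)OCn1c(Cl)nc2c(Cl)c(Cl)ccc21` gives > 100000 nM, which is a limit and not a number. Compound 2 `Nc1nc2cc(Cl)c(Cl)cc2n1COC(CO)CO` gives > 100000 nM, again only a limit. Compound 3 `CN(C)c1nc2c(Cl)c(Cl)ccc2n1COC(CO)CO` gives > 100000 nM, a limit as well. Taken together, the record so far is the limit of > 100000 nM in this assay, at which 3 of the 3 values shown sit. For the measured compounds named here, compound 2 therefore has no exact position, and no measured compound can be ranked against it.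

Compound 4 `OCC(CO)OCn1c(S)nc2cc(Cl)c(Cl)cc21` differs from compound 2 in one place: sulfanyl in place of amino on an aromatic carbon. Sulfanyl replaces amino on an aromatic carbon, between two ring nitrogen atoms. The closest measured change is also a swap of one group on an aromatic carbon, a step that the two limits leave unreadable from compound 1 to compound 3. That step has no readable size, so it gives no guide to the size or direction of this new swap. Going by the values given here, no measured compound carries a sulfanyl group. The safest expectation is that compound 4 stays near the same limit, with at most weak inhibition showing up as a number. The estimate is a number no higher from compound 2 to compound 4 (the limit leaves the size open), which means no expected shift beyond the usual scatter. For compound 4 the expected value is 100000 nM, with an estimated range from 30000 nM to 200000 nM.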

Compound 4, half-maximal inhibitory concentration: > 100000 nM
Compound 4: a limit, no number (the forecaster's own chance of this, stated with the estimate: 75%); the middle value lies on the limit itself.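

Compound 2 and compound 4 both stand only as limits in this assay, so no step can be read from compound 2 to compound 4, and sulfanyl in place of amino has no measurable size. The compounds shown leave open how strongly any of them inhibits, and which change would give an exact number; the record remains: the limit of > 100000 nM in this assay, at which 4 of the 4 values shown sit.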